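Aryl triazole in place of ethynyl: expected loss of inhibition

The source may report more compounds than this note shows. Statements on the series, on what has been measured and on what is new or still open speak of the compounds shown alone.

Within the data shown here, in a functional assay on A549 cells (Homo sapiens) for inhibition, read by sulforhodamine B assay, with a stated time of 48 h, tested at 50 uM (on this read-out higher numbers stand for more inhibition of growth at the one concentration tested and lower numbers for less inhibition of growth), compound 3 `C#CCO/N=C1/C[C@@H](c2ccc(OC)cc2)Oc2cc(OC)c(CC=C(C)C)cc21` gives 64% and stands highest of the three numbers so far. Compound 1 `COc1ccc([C@@H]2C/C(=N/OCc3cn(-c4ccc(O)cc4)nn3)c3cc(CC=C(C)C)c(OC)cc3O2)cc1` gives 52% there and compound 2 `COc1ccc([C@@H]2C/C(=N/OCc3cn(-c4cccc(CO)c4)nn3)c3cc(CC=C(C)C)c(OC)cc3O2)cc1` gives 43% in the same test.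

Compound 4 `COc1ccc([C@@H]2C/C(=N/OCc3cn(-c4cccnc4Cl)nn3)c3cc(CC=C(C)C)c(OC)cc3O2)cc1` carries 1-(2-chloropyridin-3-yl)-1H-1,2,3-triazol-4-yl in place of ethynyl on a saturated chain carbon bound to an oxygen on an unsaturated carbon, and 1-(2-chloropyridin-3-yl)-1H-1,2,3-triazol-4-yl in place of ethynyl on a saturated chain carbon bound to an oxygen on an unsaturated carbon gives the count of that change.

The nearest measured step is a number 12 percentage points higher from compound 1 to compound 3 (beyond the scatter) and it makes the same kind of exchange in reverse, since an aryl triazole leaves and ethynyl enters. The step of a number 9 percentage points lower from compound 1 to compound 2 (within the scatter) changes only the group on the aromatic nitrogen. Among the measured compounds shown here, no measured compound carries a chloropyridinyl group.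

A modest fall in this assay is therefore expected, similar in size to the reverse of the step from the aryl triazole compound 1 to ethynyl. The estimate is a number 17 percentage points lower from compound 3 to compound 4 (beyond the scatter) as the expected change. For compound 4 the estimated value is 47% with an expected range of 33% to 61% in repeated measurements.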

Compound 4, percent growth inhibition at one concentration: 58%
Compound 4: middle estimate off by 11 percentage points, on the low side; the range from low to high includes it.
By their numbers in this assay, from the lowest: compounds 2, 1, 4 and 3 (each within the scatter of the next, the first and the last beyond it).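

In this assay, exchanging ethynyl for an aryl triazole on this saturated chain carbon bound to an oxygen need not separate a pair: a number 6 percentage points lower from compound 3 to compound 4 (within the scatter), whereas the earlier pair gave a number 12 percentage points higher from compound 1 to compound 3 (beyond the scatter). The group on the aromatic nitrogen therefore decides how such a pair reads, and 2-chloropyridin-3-yl gives a number 15 percentage points higher from compound 2 to compound 4 (beyond the scatter), a step beyond the scatter against 3-(hydroxymethyl)phenyl. Against 4-hydroxyphenyl the same group gives a number 6 percentage points higher from compound 1 to compound 4 (within the scatter), so those two are not separated. Nothing available explains these differences.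

Open, from the compounds shown here alone, is how the triazole reads with a plain phenyl, a 3-carboxyphenyl or an aminomethyl-bearing phenyl on the aromatic nitrogen. Also open, going by these compounds, is whether the chlorine of 2-chloropyridin-3-yl contributes, which a pair with pyridin-3-yl would address.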